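This account rests on a few compounds, and the source may have more. Where it says the series, first, only, none or still open, it means among the compounds named here.

Compound 2 `Cc1cc(C)c(NC(=O)N(Cc2ccc(-c3nnc(C)o3)cc2)C2CCCCCC2)c(C)c1` gives 27 nM in an assay on microsomes from intestine for inhibition of acyl-CoA:cholesterol acyltransferase (Oryctolagus cuniculus) (a higher number here means a weaker inhibitor, a lower number a stronger inhibitor), the second highest of three numbers: compound 3 `CN(C)c1ccc(CN(Cc2cccc(-c3cc[nH]n3)c2)C(=O)Nc2c(F)cc(F)cc2F)cc1` gives 12 nM, and compound 1 `Cc1cc(C)c(NC(=O)N(Cc2ccc(-c3n[nH]c(C)n3)cc2)C2CCCCCC2)c(C)c1` gives 120 nM. Compound 4 `Cc1cc(C)c(NC(=O)N(Cc2ccc(-c3cccs3)cc2)C2CCCCCC2)c(C)c1` differs from compound 2 in one place: thiophen-2-yl in place of 5-methyl-1,3,4-oxadiazol-2-yl on an aromatic carbon. Within the data shown here, one measured step bears on this place, an exchange of one five-membered heteroaryl for another on the same core: a 4.4-fold lower number from compound 1 to compound 2 (0.65 log units; beyond the scatter). Among the measured compounds shown here, that step shows the group here can shift the number beyond the scatter, but no measured pair includes thiophen-2-yl, and compound 3 rests on a different core. A modest step is therefore expected, its direction uncertain (a 1.5-fold higher number from compound 2 to compound 4 (0.17 log units; within the scatter)). For compound 4 the estimate in this assay is 40 nM, within a range from 12 nM to 130 nM.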

Compound 4, half-maximal inhibitory concentration: 22 nM
For compound 4 the middle estimate is 1.8-fold (0.26 log units) above the measured one; the measured number falls inside the stated range.
By their numbers in this assay, from the lowest: compounds 3, 4 and 2 (each within the scatter of the next, the first and the last beyond it); then compound 1.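

In this assay, thiophen-2-yl in place of 5-methyl-1,3,4-oxadiazol-2-yl gives a 1.2-fold lower number from compound 2 to compound 4 (0.09 log units; within the scatter), so on this aromatic carbon a ring with one hetero atom and one hydrogen-bond acceptor matches one with three of each. The 5-methyl-1H-1,2,4-triazol-3-yl group of compound 1 stands apart from both, with a 5.5-fold lower number from compound 1 to compound 4 (0.74 log units; beyond the scatter) as the step to thiophen-2-yl. No measurement shown gives a reason for this. The compounds shown leave open whether an aromatic ring is needed here at all, and how an amine or a carboxylic acid on this carbon would score.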